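Swapping an ether link for an aminomethyl link

The source may hold more compounds than are shown below. What is called first, only, known or untested is meant among the compounds shown, and "the series" means these compounds.

In an assay on cells for displacement of a labelled ligand from metabotropic glutamate receptor 2 (Homo sapiens), read by scintillation counting, with a stated time of 60 min (on this read-out lower numbers stand for stronger inhibition and higher numbers for weaker inhibition), the three measured compounds gave the following numbers:

Compound 1 `CC(C)Nc1ccc(-c2ccn3c(CC4CC4)nnc3c2C(F)(F)F)cc1Cl`: 3.89 nM
Compound 2 `Clc1cc(-c2ccn3c(CC4CC4)nnc3c2Cl)ccc1OC1CCOCC1`: 22.9 nM
Compound 3 `FC(F)(F)c1c(-c2ccc(OC3CCOCC3)c(Cl)c2)ccn2c(CC3CC3)nnc12`: 5.25 nM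

Compound 3 sits second highest of these three numbers. Compound 1 lies within the scatter of it (a 1.3-fold higher number from compound 1 to compound 3 (0.13 log units; within the scatter)), while compound 2 stands apart (a 4.4-fold lower number from compound 2 to compound 3 (0.64 log units; beyond the scatter)). Compound 4 `FC(F)(F)c1c(-c2ccc(CNC3CCOCC3)c(Cl)c2)ccn2c(CC3CC3)nnc12` carries ((oxan-4-yl)amino)methyl in place of (oxan-4-yl)oxy on an aromatic carbon. Among the compounds with values here, only the step from compound 1 to compound 3 touches this same aromatic carbon, and there the exchange of one group for another left the number within the scatter; the step from compound 2 to compound 3 concerns a different position and does not bear on this exchange. Because a 1.3-fold higher number from compound 1 to compound 3 (0.13 log units; within the scatter) stayed within the scatter, compound 4 is expected to stay close, with a 1.3-fold higher number from compound 3 to compound 4 (0.12 log units; within the scatter). The estimate for compound 4 is 7 nM, with a range from 2.5 nM to 25 nM.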

Compound 4, inhibition constant: 61.7 nM
Estimate against measurement, compound 4: 8.8-fold (0.95 log units) below; the measured number lies above the stated range.
By their numbers in this assay, from the lowest: compounds 1 and 3 (each within the scatter of the next); then compound 2; then compound 4.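

At this aromatic carbon, ortho to a chloro group, the exchange of groups is not always as quiet as the earlier step suggested: ((oxan-4-yl)amino)methyl brings a 12-fold higher number from compound 3 to compound 4 (1.07 log units; beyond the scatter) and also a 16-fold higher number from compound 1 to compound 4 (1.20 log units; beyond the scatter) in this series. The same oxane ring therefore gives a very different number once its link to the aromatic ring changes. No measurement here accounts for this shift.

From the compounds shown here alone, whether the added carbon or the nitrogen carries the change stays open, as neither varies alone. A directly attached (oxan-4-yl)amino group would help separate the two.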